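A Second Halogen Pattern on the Benzyl Arm

The source may report more compounds than this note shows. Statements on the series, on what has been measured and on what is new or still open speak of the compounds shown alone.

Of the compounds shown here, three sharing one core have been measured in an assay on FRT cells for positive allosteric modulation of Cystic fibrosis transmembrane conductance regulator variant N1303K (Homo sapiens), in the presence of a further agent that is not named here; on this read-out higher numbers stand for an effect only at larger amounts of compound and lower numbers for an effect already at smaller amounts. Compound 1 `COc1ccc2[nH]c3c(c2c1)CCNC31CCN(Cc2ccccc2)CC1` carries a plain phenyl on a saturated chain carbon bound to an amine nitrogen in a ring; in this assay compound 1 gives 12600 nM. Compound 2 `COc1ccc2[nH]c3c(c2c1)CCNC31CCN(Cc2ccc(Cl)cc2Cl)CC1` gives 1800 nM, and compound 3 `COc1ccc2[nH]c3c(c2c1)CCNC31CCN(Cc2cc(F)cc(Cl)c2)CC1` gives 2500 nM. Among these three numbers compound 3 stands second highest, closest to compound 2 and furthest from compound 1. Putting 2,4-dichlorophenyl in place of phenyl brought a 7.0-fold lower number from compound 1 to compound 2 (0.85 log units; beyond the scatter); putting 3-chloro-5-fluorophenyl there instead brought a 5.0-fold lower number from compound 1 to compound 3 (0.70 log units; beyond the scatter). Between the two compounds that each carry two halogens the step was only a 1.4-fold higher number from compound 2 to compound 3 (0.14 log units; within the scatter).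

Compound 4 `COc1ccc2[nH]c3c(c2c1)CCNC31CCN(Cc2ccc(Br)c(F)c2)CC1` is the next member: 4-bromo-3-fluorophenyl in place of 3-chloro-5-fluorophenyl on a saturated chain carbon bound to an amine nitrogen in a ring. The ring again carries two halogens, only different ones. Among the measured compounds shown here, the steps that bear on this change are the two from compound 1, both modest and in the same direction, and the step from compound 2 to compound 3, which stayed within the scatter. A number close to that of compound 3 is therefore expected for compound 4, and the expected step of no change at the digits printed from compound 3 to compound 4 (within the scatter) is none beyond the scatter. The estimate for compound 4 is 2500 nM, with a range from 1000 nM to 6000 nM.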

Compound 4, half-maximal effective concentration: 1800 nM
The estimate for compound 4 lay 1.4-fold (0.14 log units) above the measured number; measured number inside the range.
By their numbers in this assay, from the lowest: compounds 2, 4 and 3 (each within the scatter of the next); then compound 1.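

In this assay a third pair of halogens on the phenyl ring, this time including a bromine, gives a result that cannot be told apart from the other two pairs: 4-bromo-3-fluorophenyl in place of 3-chloro-5-fluorophenyl gives a 1.4-fold lower number from compound 3 to compound 4 (0.14 log units; within the scatter) and in place of 2,4-dichlorophenyl gives no change at the digits printed from compound 2 to compound 4 (within the scatter) so neither swap can be read as a real change. Set against the plain phenyl, the same group gives a 7.0-fold lower number from compound 1 to compound 4 (0.85 log units; beyond the scatter) which means that compounds 2, 3 and 4 all lie beyond the scatter from compound 1 while staying within it of one another, and none of the four compounds goes against this pattern, even though the halogens differ in kind and in where the names place them. Nothing measured here explains why these halogen-bearing rings give lower numbers than the plain phenyl.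

From the compounds shown here alone, whether a single chlorine on the phenyl ring would bring the same drop, or whether two halogens are needed, remains open. Also open, going by these compounds, is how the number would respond to a group that is not a halogen on that ring, such as a nitrile or a carboxylic acid.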